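Swapping methylamino for hydroxymethyl: a cytotoxicity forecast

The source may report more compounds than this note shows. Statements on the series, on what has been measured and on what is new or still open speak of the compounds shown alone.

Measured so far, in an ADME assay on MT2 cells (Homo sapiens) for cytotoxicity; a higher number here means that more compound is tolerated, a lower number that less compound is tolerated:
Compound 1 `COc1ncnc(Nc2ccc(C#N)c(OCC=C(C)C)c2)n1` gives 42000 nM.
Compound 2 `CNc1ccnc(Nc2ccc(Cl)c(OCC=C(C)C)c2)n1` gives 690 nM.
Compound 3 `COc1cc(N)nc(Nc2ccc(Cl)c(OCC=C(C)C)c2)n1` gives 19000 nM.

Among these three, compound 2 stands lowest in this assay: compound 3 sits a good way above it, and compound 1 further still, both gaps well beyond the scatter of repeated runs. Compound 2 is therefore the least tolerated of the three measured compounds.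

Compound 4 `CC(C)=CCOc1cc(Nc2nccc(CO)n2)ccc1Cl` has not yet been measured. It differs from compound 2 in one place: hydroxymethyl in place of methylamino on an aromatic carbon.

For the measured compounds named here, no pair of measured compounds differs in just one place, so there is no measured step to lean on. What the data do show is that compound 2 is the odd one out, with compounds 1 and 3 both far more tolerated. The writer therefore expects the step of a 2.9-fold higher number from compound 2 to compound 4 (0.46 log units; beyond the scatter) to go upward, toward a higher tolerated concentration, though its size is uncertain and a result within the scatter would not surprise. For compound 4 the estimate in this assay is 2000 nM, with a range from 400 nM to 12000 nM.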

Compound 4, half-maximal cytotoxic concentration: 220 nM
Compound 4: middle estimate off by 9.1-fold (0.96 log units), on the high side, and the stated range ends above it.
By their numbers in this assay, from the lowest: compound 4; then compound 2; then compound 3; then compound 1.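

In this assay, hydroxymethyl in place of methylamino on this aromatic carbon, next to the ring nitrogen, gives a 3.1-fold lower number from compound 2 to compound 4 (0.50 log units; beyond the scatter). For the compounds shown here, this is the first step here that changes one place only, and it shows that the position responds to this swap, with less compound tolerated after it. The two groups match in heavy-atom count, in hydrogen-bond donors and acceptors and in having no net charge, so those counts alone do not settle the number here, and nothing available explains the step.

Going by these compounds, whether a plain amino group or a methoxymethyl group at this position would move the number in the same direction remains open. So does whether the same swap would give a similar step on another core.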